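A few compounds are considered here, and "the series" means these few. Any claim that something is new, unique, unknown or untested is made for them only; others in the source may bear on it.

Measured so far in the series:

Compound 1, `Cc1nnc(SCC(=O)N/N=c2/scc(-c3ccccc3)n2-c2ccccc2)s1`, in an ADME assay on NIH3T3 cells (Mus musculus) for cytotoxicity, read by MTT assay, with a stated time of 24 h (a lower number here means a stronger inhibitor, a higher number a weaker inhibitor), gives 197 ug/mL.
Compound 2, `COc1ccc(-c2cs/c(=N/NC(=O)CSc3nnnn3C)n2-c2ccccc2)cc1`, in this assay gives 45 ug/mL.

Compound 2 holds the lowest of the two numbers in this assay. Its nearest neighbour is compound 1, whose number stands higher by a margin beyond the scatter of repeated measurements. Within the data shown here, no pair that differs in a single place has been measured, so no step size is yet known from the data.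

Compound 3, `COc1ccc(-c2cs/c(=N/NC(=O)CSc3nnc(C)s3)n2-c2ccccc2)cc1`, is the next entry for this assay. It is derived from compound 2 by the change (5-methyl-1,3,4-thiadiazol-2-yl in place of 1-methyl-1H-tetrazol-5-yl on a sulfur). Compound 3 thus carries the same 5-methyl-1,3,4-thiadiazol-2-yl group that compound 1 carries, while keeping the rest of compound 2 unchanged.

Without a measured single-place step, the expectation rests only on the two values shown. Compound 1, with the thiadiazole, gives 197 ug/mL, and compound 2, with the tetrazole, gives 45 ug/mL. The step of a 2.1-fold higher number from compound 2 to compound 3 (0.32 log units; beyond the scatter) is expected to move the number upward, by a moderate amount that may or may not exceed the scatter. Compound 3 is therefore estimated at 95 ug/mL, within a range from 40 ug/mL to 230 ug/mL.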

Compound 3, half-maximal inhibitory concentration: 300 ug/mL
Compound 3: the middle estimate sits 3.2-fold (0.50 log units) below what was measured; the measured number lies above the stated range.
By their numbers in this assay, from the lowest: compound 2; then compounds 1 and 3 (each within the scatter of the next).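

Swapping 1-methyl-1H-tetrazol-5-yl for 5-methyl-1,3,4-thiadiazol-2-yl on a sulfur whose other neighbour is a saturated chain carbon gives, in this assay, a 6.7-fold higher number from compound 2 to compound 3 (0.82 log units; beyond the scatter) and so provides the first single-place reading at this position, showing that the number responds to the group on this sulfur. Methoxy in place of hydrogen on an aromatic carbon, with 5-methyl-1,3,4-thiadiazol-2-yl held on the sulfur, gives a 1.5-fold higher number from compound 1 to compound 3 (0.18 log units; within the scatter) and stays within the scatter, so within these two pairs only the exchange on the sulfur registers beyond it. No measurement at hand accounts for the size of either step.

On these data alone, it remains open whether the exchange on the sulfur would give a step of similar size on a core carrying hydrogen instead of methoxy, and whether the tetrazole reading reflects that ring specifically or would be shared by other groups on the sulfur, such as a plain methyl, a longer alkyl chain or a chain ending in a carboxylic acid. As far as these compounds go, the response at the aromatic carbon is also open for groups other than methoxy, such as fluorine or an amine.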